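Dropping the chloro from compound 1: an expected small step

This account rests on a few compounds, and the source may have more. Where it says the series, first, only, none or still open, it means among the compounds named here.

Going by the values given here, compound 1 `COc1cc(/C=C/C(=O)c2cccc(-n3cc(-c4ccc(Cl)cc4)[nH]c3=O)c2)cc(OC)c1OC` is one of three compounds measured in a functional assay on SF-539 cells (Homo sapiens) for inhibition (a lower number here means a stronger inhibitor of growth, a higher number a weaker inhibitor of growth), and it gives 3490 nM. Among those three numbers this is the highest: the nearest is compound 2 `O=C(/C=C/c1cccc(O)c1)c1cccc(-n2cc(-c3ccccc3)[nH]c2=O)c1`, which in this assay gives 1980 nM, a gap within the scatter, while the furthest is compound 3 `O=C(/C=C/c1cccc(O)c1)c1cccc(-n2cc(-c3ccc(Cl)cc3)[nH]c2=O)c1`, which gives 1680 nM, a gap beyond the scatter. Compound 4 `COc1cc(/C=C/C(=O)c2cccc(-n3cc(-c4ccccc4)[nH]c3=O)c2)cc(OC)c1OC` is not yet measured. It differs from compound 1 by hydrogen in place of chloro on an aromatic carbon, on the aromatic carbon para to a large group of the shared core. Among the compounds with values here, one measured step bears directly on this change, in the reverse direction: a 1.2-fold lower number from compound 2 to compound 3 (0.07 log units; within the scatter). Since adding the chloro changed little there, removing it from compound 1 is expected to change little here, perhaps nudging the number slightly upward. The step this estimate means is a 1.2-fold higher number from compound 1 to compound 4 (0.08 log units; within the scatter), expected to remain within the scatter. Compound 4 is therefore estimated at 4200 nM, with a range from 2000 nM to 8500 nM.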

Compound 4, concentration for 50% growth inhibition: 1680 nM
Compound 4: the middle estimate sits 2.5-fold (0.40 log units) above what was measured; measured number below the stated range.
By their numbers in this assay, from the lowest: compounds 3, 4, 2 and 1 (each within the scatter of the next, the first and the last beyond it).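

In this assay, the change from 4-chlorophenyl to phenyl gives a 2.1-fold lower number from compound 1 to compound 4 (0.32 log units; beyond the scatter), so the aromatic carbon para to a large group is not silent on every core. Going by these compounds alone, the earlier step, with its chloro in place of hydrogen, had stayed within the scatter, and this one is the first at this position to go beyond it, though only modestly. Even so, the two steps cannot be told apart as a true difference between the cores: the same change on two cores in this assay, a 1.2-fold lower number (0.07 log units; within the scatter) from compound 2 to compound 3 and a 2.1-fold higher number (0.32 log units; beyond the scatter) from compound 4 to compound 1, 2.4-fold (0.39 log units) apart, within the scatter of two such steps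

The compounds shown carry only hydrogen or chloro at this place, so it remains open whether a fluoro, a methoxy or an amine there would move the number on either core. From the compounds shown here alone, whether the step seen here would hold in any other assay also remains open.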